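Chloroacetyl Urea Analogues Against HT-29 Cell Growth

A few compounds are considered here, and "the series" means these few. Any claim that something is new, unique, unknown or untested is made for them only; others in the source may bear on it.

Compound 1 `CC(C)(C)c1ccc(CNC(=O)NCCCCl)cc1` and compound 3 `CC(C)(C)c1ccc(CNC(=O)NC(=O)CCl)cc1` share one core, while compound 2 `CCCCCc1cccc(NC(=O)NCCCCl)c1` and compound 4 `CCCCCc1cccc(NC(=O)NC(=O)CCl)c1` share another; the difference between the two cores is not broken down here. In a functional assay on HT-29 cells (Homo sapiens) for antiproliferative activity, with a stated time of 48 h (on this read-out lower numbers stand for stronger inhibition and higher numbers for weaker inhibition), compound 1 gives 19000 nM, and compound 3 gives 7100 nM. The change that separates them, ((chloromethyl)carbonyl in place of 3-chloropropyl on an amide-type nitrogen), produced a 2.7-fold lower number from compound 1 to compound 3 (0.43 log units; beyond the scatter). Compound 2 gives 28000 nM in this assay; this number and that of compound 1 lie within the scatter of each other, whereas compound 3 lies beyond it. Compound 4 carries the same change relative to compound 2, namely ((chloromethyl)carbonyl in place of 3-chloropropyl on an amide-type nitrogen). The place of the change is described identically in both pairs, so it is the same change, seen in measured form only once. Going by the values given here, for compound 4 a step of about the earlier size is expected, a 2.5-fold lower number from compound 2 to compound 4 (0.41 log units; beyond the scatter), because a 2.7-fold lower number from compound 1 to compound 3 (0.43 log units; beyond the scatter) is the only measured instance and nothing in the data points the other way. Compound 4 is therefore estimated at 11000 nM in this assay, with a range from 5000 nM to 25000 nM.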

Compound 4, half-maximal inhibitory concentration: 8400 nM
Compound 4: middle estimate off by 1.3-fold (0.12 log units), on the high side; the measured number falls inside the stated range.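

In this assay, placing (chloromethyl)carbonyl instead of 3-chloropropyl on the amide-type nitrogen again gives a lower number (a 3.3-fold lower number from compound 2 to compound 4 (0.52 log units; beyond the scatter)). Set beside the earlier step, the change carries over from the core of compound 1 to the core of compound 2 with no difference that these data can separate: the same change on two cores in this assay, a 2.7-fold lower number (0.43 log units; beyond the scatter) from compound 1 to compound 3 and a 3.3-fold lower number (0.52 log units; beyond the scatter) from compound 2 to compound 4, 1.2-fold (0.10 log units) apart, within the scatter of two such steps. This agreement rests on just these two pairs in a single cell assay, so it does not show that the step would hold on any other core, nor does it explain why the change lowers the number.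

The compounds shown leave open whether a similar step would appear with a longer chain carrying the carbonyl, or with an amine or a fluorine in place of the chlorine. They also leave open how the other differences between the two cores bear on the numbers, and whether the same change would have a similar effect in other cell lines.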